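Notes on the step from compound 3 to compound 4

The compounds below may be only part of what the source reports. "The series", "measured", "known", "first", "only" and "open" are said of these compounds alone.

Values in a functional assay on HCT-116 cells (Homo sapiens) for antiproliferative activity, read by MTT assay, with a stated time of 24 h; on this read-out lower numbers stand for stronger inhibition and higher numbers for weaker inhibition:
compound 1 `C=CCOc1ccc2c(=O)c(-c3cc(OC)c(OC)cc3OC)coc2c1`: 6600 nM
compound 2 `COc1cc(OC)c(-c2coc3cc(OCc4ccc([N+](=O)[O-])cc4)ccc3c2=O)cc1OC`: > 10000 nM (a limit)
compound 3 `COc1cc(OC)c(-c2coc3cc(OCc4ccccc4Cl)ccc3c2=O)cc1OC`: 2450 nM

Compound 3 holds the lower of the two actual numbers at 2450 nM, with compound 1 at 6600 nM. For compound 2, > 10000 nM is a limit.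

Compound 4 `COc1cc(OC)c(-c2coc3cc(OCc4cccc(Br)c4)ccc3c2=O)cc1OC` is not yet measured. It carries 3-bromophenyl in place of 2-chlorophenyl on a saturated chain carbon bound to an oxygen on an aromatic ring.

Among the compounds with values here, the measured exchanges at this same place are the only guide. They comprise a 2.7-fold lower number from compound 1 to compound 3 (0.43 log units; beyond the scatter) and an at least 4.0-fold lower number from compound 2 to compound 3 (0.61 log units; beyond the scatter), while an at least 1.5-fold higher number from compound 1 to compound 2 (0.18 log units; that floor lies within the scatter) rests on a limit, as noted in the limit of > 10000 nM in this assay, at which 1 of the 3 values shown sits. Within the data shown here, the group at this place can therefore move the number, but no measured compound carries bromine, and no measured step isolates this exchange. With compound 3 starting from the low end of the series at 2450 nM, a small upward drift is expected rather than a further drop. In this assay the expected step is a 1.4-fold higher number from compound 3 to compound 4 (0.15 log units; within the scatter). For compound 4 the estimate is 3500 nM, with an expected range of 1300 nM to 9000 nM.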

Compound 4, half-maximal inhibitory concentration: 1200 nM
Estimate against measurement, compound 4: 2.9-fold (0.46 log units) above; measured number outside the range, below it.
By their numbers in this assay, from the lowest: compound 4; then compound 3; then compound 1. At a limit, above all of these: compound 2.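

In this assay, the step of a 2.0-fold lower number from compound 3 to compound 4 (0.31 log units; beyond the scatter) lies beyond the scatter, so this place on a saturated chain carbon bound to an oxygen on an aromatic ring still responds when one halogenated phenyl replaces another, with the same heavy-atom count and no hydrogen-bond donors or acceptors on either group. The step of a 5.5-fold lower number from compound 1 to compound 4 (0.74 log units; beyond the scatter) is larger than the earlier step from vinyl to 2-chlorophenyl, and among the compounds with actual numbers compound 4 now holds the lowest in this assay, which extends the range reached at this place by aryl exchange alone. The step of an at least 8.3-fold lower number from compound 2 to compound 4 (0.92 log units; beyond the scatter) widens the known gap to the 4-nitrophenyl compound but gives only a floor, since the value of compound 2 is a limit: the limit of > 10000 nM in this assay, at which 1 of the 4 values shown sits.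

The exchange from compound 3 to compound 4 changes the halogen and its place on the phenyl ring together, so the compounds shown cannot separate the two; 3-chlorophenyl and 2-bromophenyl would do so. As far as these compounds go, whether the halogen is needed at all also stays open, as neither unsubstituted phenyl nor a group such as 3-aminophenyl or a longer chain such as 2-phenylethyl appears among them.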